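This account rests on a few compounds, and the source may have more. Where it says the series, first, only, none or still open, it means among the compounds named here.

In a functional assay on HCT-116 cells (Homo sapiens) for inhibition, read by CCK-8 assay, with a stated time of 48 h (a higher number here means a weaker inhibitor, a lower number a stronger inhibitor), three compounds have been measured so far:

Compound 1 `COc1cc(-c2ccnc3cc(-c4ccccc4)nn23)cc(OC)c1OC`: 3880 nM
Compound 2 `COc1cc(-c2ccnc3cc(-c4cn(C)c5ccccc45)nn23)cc(OC)c1OC`: 762 nM
Compound 3 `COc1cc(-c2ccnc3cc(-c4cn(C(=O)OC(C)(C)C)c5ccccc45)nn23)cc(OC)c1OC`: 5720 nM

Compound 2 gives the lowest of the three numbers. The nearest is compound 1, the step of a 5.1-fold lower number from compound 1 to compound 2 (0.71 log units; beyond the scatter) placing compound 2 well ahead of it; the furthest is compound 3, as the step of a 7.5-fold higher number from compound 2 to compound 3 (0.88 log units; beyond the scatter) shows. Both steps lie beyond the scatter.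

The next compound, compound 4 `COc1ccc(-c2cc3nccc(-c4cc(OC)c(OC)c(OC)c4)n3n2)cc1N`, differs from compound 2 at the same position that separated compound 1 from compound 2: 3-amino-4-methoxyphenyl in place of 1-methyl-1H-indol-3-yl on an aromatic carbon. The step from compound 1 to compound 2 bears most directly on this change, since it also exchanged a phenyl ring for the larger fused group at that carbon. The step from compound 2 to compound 3 touched only the substituent on the indole nitrogen and is less relevant, though it confirms that this region responds to changes beyond the scatter. The incoming 3-amino-4-methoxyphenyl is a substituted six-membered aromatic ring of carbon only, closer to the phenyl of compound 1 than to the 1-methyl-1H-indol-3-yl of compound 2. A return toward the number of compound 1, which gave 3880 nM, is expected, probably not all the way. Compound 4 is therefore estimated at 2000 nM, within 600 nM to 6500 nM, which means an expected step of a 2.6-fold higher number from compound 2 to compound 4 (0.42 log units; beyond the scatter).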

Compound 4, half-maximal inhibitory concentration: 251 nM
For compound 4 the middle estimate is 8.0-fold (0.90 log units) above the measured one; the whole stated range lies above it.
By their numbers in this assay, from the lowest: compound 4; then compound 2; then compounds 1 and 3 (each within the scatter of the next).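

In this assay, the carbon on the five-membered aromatic ring does not depend on a fused group for a low number: replacing 1-methyl-1H-indol-3-yl with 3-amino-4-methoxyphenyl gives a 3.0-fold lower number from compound 2 to compound 4 (0.48 log units; beyond the scatter). For the compounds shown here, the ring type stays the same between phenyl and 3-amino-4-methoxyphenyl, yet adding the amino and methoxy substituents to that ring gives a 15-fold lower number from compound 1 to compound 4 (1.19 log units; beyond the scatter), so at this position the substituents on a single six-membered aromatic ring can change the number substantially, a point the earlier compounds could not show. Nothing measured here explains why this change lowers the number.

The compounds shown do not separate the contributions of the two substituents, since neither 3-aminophenyl nor 4-methoxyphenyl stands among them, and it remains open whether the two act together or one alone accounts for the step. From the compounds shown here alone, it is also open how the number would respond to a change at the amino group itself, such as a hydroxyl in its place or an acetamide formed on its nitrogen, or to a longer alkoxy chain in place of the methoxy.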